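A few compounds are considered here, and "the series" means these few. Any claim that something is new, unique, unknown or untested is made for them only; others in the source may bear on it.

Measured compounds:
compound 1 `COc1ccc(-c2cc(/C=C/C(=O)c3ccc(N)cc3)[nH]n2)cc1`: 89%
compound 2 `COc1cc(-c2cc(/C=C/C(=O)c3ccc(N)cc3)[nH]n2)cc(OC)c1OC`: 100%

Of the compounds shown here, two have been measured in a functional assay on IGROV-1 cells (Homo sapiens) for cytotoxicity, read by sulforhodamine B assay, with a stated time of 48 h, tested at 1 uM; on this read-out lower numbers stand for a stronger effect and higher numbers for a weaker effect at the one concentration tested. Compound 1 gives 89% and compound 2 gives 100%. Compound 2 thus stands at the highest of the two numbers, meaning the weaker effect, and its nearest neighbour, compound 1, lies lower by a gap beyond the scatter of repeated measurements.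

Compound 3 `COc1ccc(-c2cc(/C=C/C(=O)c3ccc(N)cc3)[nH]n2)cc1OC` has not yet been measured. It differs from compound 2 in one place: hydrogen in place of methoxy on an aromatic carbon. Among the measured compounds shown here, with no measured pair of this kind to draw on, the expectation rests on compound 1 and compound 2 alone. Compound 3 carries fewer methoxy groups than compound 2 but more than compound 1, so a small step downward, a number 5 percentage points lower from compound 2 to compound 3 (within the scatter), is expected, likely within the scatter. Compound 3 is therefore estimated at 95%, with a range from 83% to 104%.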

Compound 3, a percentage reported as activity, at one concentration (the size of the read-out at that concentration, not a potency): 100%
Compound 3: middle estimate off by 5 percentage points, on the low side; the measured number falls inside the stated range.
By their numbers in this assay, from the lowest: compound 1; then compounds 2 and 3 (each within the scatter of the next).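

In this assay, no change at the digits printed from compound 2 to compound 3 (within the scatter), so on this ring, hydrogen and methoxy at a carbon ortho to a methoxy group and meta to a large group cannot be told apart when the ring's other methoxy groups are those of compound 2. The same kind of change read the other way, methoxy in place of hydrogen on an aromatic carbon, does register when it starts from compound 1: a number 11 percentage points higher from compound 1 to compound 3 (beyond the scatter), which on this read-out means a weaker effect at the one concentration tested. The compounds shown offer no explanation for this difference between the two steps. Still open, as far as these compounds go, is how a hydroxy group, an amine or a longer chain such as ethoxy would read on this ring carbon. Also open, from the compounds shown here alone, is whether removing the methoxy group of compound 1 would shift the number.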